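The source may report more compounds than this note shows. Statements on the series, on what has been measured and on what is new or still open speak of the compounds shown alone.

Within the data shown here, compound 3 `COc1cc(NC(=O)c2cn(Cc3ccc(F)cc3Cl)c3ccc(=O)[nH]c3c2=O)cc(OC)c1OC` is one of only two compounds with a plain number in an in vitro assay on Sf21 cells for inhibition of high affinity 3',5'-cyclic-AMP phosphodiesterase 7A (Homo sapiens), read by scintillation proximity assay, with a stated time of 30 min (on this read-out higher numbers stand for weaker inhibition and lower numbers for stronger inhibition), where compound 3 gives 192 nM. Compound 1 `COc1cc(NC(=O)c2cn(Cc3ccccc3F)c3ccc(=O)[nH]c3c2=O)cc(OC)c1OC` gives 206 nM in this assay, and the step of a 1.1-fold lower number from compound 1 to compound 3 (0.03 log units; within the scatter) shows the two sit level. For compound 2 `COc1cc(NC(=O)c2cn(Cc3ccccc3Br)c3ccc(=O)[nH]c3c2=O)cc(OC)c1OC` this assay reports only a limit, > 1000 nM. Compound 4 `COc1cc(NC(=O)c2cn(Cc3ccc(F)cc3)c3ccc(=O)[nH]c3c2=O)cc(OC)c1OC` differs from compound 3 in one place: hydrogen in place of chloro on an aromatic carbon. Among the measured compounds shown here, no measured step removes a halogen outright; the closest, an at least 4.8-fold higher number from compound 1 to compound 2 (0.68 log units; beyond the scatter) and an at least 5.2-fold lower number from compound 2 to compound 3 (0.71 log units; beyond the scatter), merely swap one halogen for another, and one of them rests on a limit (the limit of > 1000 nM in this assay, at which 1 of the 3 values shown sits). The step from compound 3 to compound 4 is therefore expected to be small, a slight weakening if anything, with a 1.7-fold higher number from compound 3 to compound 4 (0.22 log units; within the scatter). Compound 4 is estimated at 320 nM, in the range 120 nM to 900 nM.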

Compound 4, half-maximal inhibitory concentration: 868 nM
Estimate against measurement, compound 4: 2.7-fold (0.43 log units) below, within the range that was stated.
By their numbers in this assay, from the lowest: compounds 3 and 1 (each within the scatter of the next); then compound 4. At a limit, above all of these: compound 2.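

Removing a halogen outright is not neutral at this place on the ring: taking away the chloro group gives a 4.5-fold higher number from compound 3 to compound 4 (0.66 log units; beyond the scatter), the first direct sign that this position matters. Moving the fluoro group from the 2-fluorophenyl to the 4-fluorophenyl arrangement agrees, with a 4.2-fold higher number from compound 1 to compound 4 (0.62 log units; beyond the scatter), so both compounds carrying a small halogen there do better than compound 4. Compound 2, with bromo there, goes against any rule that any halogen helps. The step that rests on its limit is an at least 1.1-fold lower number from compound 2 to compound 4 (0.06 log units; that floor lies within the scatter), and it fixes no order: the limit of > 1000 nM in this assay, at which 1 of the 4 values shown sits.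

Going by these compounds, whether a methyl group at this place could replace chloro remains open. So does whether a plain 2-chlorophenyl group, without the fluoro group, would match compound 3.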